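Branching the ester chain on a furan-bearing core

A few compounds are considered here, and "the series" means these few. Any claim that something is new, unique, unknown or untested is made for them only; others in the source may bear on it.

Of the compounds shown here, three sharing one core have been tested in an assay on membranes from HeLa cells for displacement of a labelled ligand from adenosine receptor A3 (Homo sapiens), read by scintillation counting, with a stated time of 180 min, tested at 1 uM; a higher number here means more inhibition at the concentration tested (going by the name of the read-out), a lower number less inhibition. Compound 1 `CC1=C(C(=O)OC(C)(C)C)C(c2ccoc2)NC(=O)N1` gives 2%, compound 2 `CCCOC(=O)C1=C(C)NC(=S)NC1c1ccco1` gives 1%, and compound 3 `CC1=C(C(=O)OCC(C)C)C(c2ccco2)NC(=S)N1` gives 10%. The number for compound 3 is nominally the top of the three, but its gaps to compound 1 and compound 2 both lie within the usual scatter, so no real order among them can be claimed; all three sit near the floor of the read-out.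

Compound 4 `CC1=C(C(=O)OC(C)(C)C)C(c2ccco2)NC(=S)N1` differs from compound 3 in one place: tert-butyl in place of isobutyl on an oxygen next to a carbonyl group. Among the compounds with values here, one measured step bears on this kind of change. It also alters the ester chain, and there a number 9 percentage points higher from compound 2 to compound 3 (within the scatter), a shift within the scatter. Within the data shown here, compound 1, which already carries a tert-butyl on the ester oxygen, shows only 2%, though it also differs from the others in its core, so no single-change step exists for it.

On this basis no step beyond the scatter is expected in this assay; the estimated change is a number 5 percentage points lower from compound 3 to compound 4 (within the scatter). Compound 4 is therefore expected to give about 5%, with a likely range from 0% to 15%.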

Compound 4, a percentage reported as inhibition, at one concentration (the size of the read-out at that concentration, not a potency): 9%
Compound 4: the middle estimate sits 4 percentage points below what was measured; the measured number falls inside the stated range.
By their numbers in this assay, from the lowest: compounds 2, 1, 4 and 3 (each within the scatter of the next).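

In this assay, moving from isobutyl to tert-butyl on an oxygen next to a carbonyl group gives a number 1 percentage points lower from compound 3 to compound 4 (within the scatter), so rearranging the same four carbons at the point where the chain meets the oxygen makes no readable difference. Comparing tert-butyl with the unbranched propyl at the same place gives a number 8 percentage points higher from compound 2 to compound 4 (within the scatter), which means that propyl, isobutyl and tert-butyl can now all be compared on this shared core, and no pair among them separates beyond the scatter. Nothing available explains why these chains read alike, and no independent measurement bears on this change.

From the compounds shown here alone, these three chains are all alike in being small and made only of carbon and hydrogen, so it remains open whether this position would respond to a clearly different group, such as a benzyl group or a longer chain like hexyl on the oxygen. The same question stands for a carboxylic acid in place of the ester, and for whether any such change could lift the number beyond the scatter at the concentration tested.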